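Swapping the aniline substituent in a weak thiourea sulfonamide

The compounds below may be only part of what the source reports. "The series", "measured", "known", "first", "only" and "open" are said of these compounds alone.

Of the compounds shown here, two have been measured in a functional assay on A549 cells (Homo sapiens) for antiproliferative activity, read by MTT assay, with a stated time of 72 h; on this read-out lower numbers stand for stronger inhibition and higher numbers for weaker inhibition. Compound 1 `COc1cc2ncnc(Nc3ccc(C(F)(F)F)cc3)c2cc1OCCCCC(=O)Nc1ccc(S(N)(=O)=O)cc1` gives 14800 nM in this assay. Compound 2 `NS(=O)(=O)c1ccc(NC(=S)Nc2ccc3ncnc(Nc4cccc(Br)c4)c3c2)cc1` gives 25000 nM, which is the higher of the two numbers; the gap to compound 1 lies within the usual scatter, so the two results cannot be ranked against each other. Compound 3 `CCc1ccc(Nc2ncnc3ccc(NC(=S)Nc4ccc(S(N)(=O)=O)cc4)cc23)cc1` differs from compound 2 in one place: 4-ethylphenyl in place of 3-bromophenyl on a nitrogen on an aromatic ring. For the measured compounds named here, no pair of measured compounds differs in just one place, so nothing here shows what such a swap does to the number. With both known values lying in the same weak region, the step expected here, a 1.3-fold lower number from compound 2 to compound 3 (0.10 log units; within the scatter), is small, with no clear direction beyond the scatter. Compound 3 is therefore estimated at 20000 nM, with a range from 6000 nM to 60000 nM.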

Compound 3, half-maximal inhibitory concentration: 24600 nM
Compound 3: the middle estimate sits 1.2-fold (0.09 log units) below what was measured, within the range that was stated.
By their numbers in this assay, from the lowest: compounds 1, 3 and 2 (each within the scatter of the next).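

In this assay, for the compounds shown here, 4-ethylphenyl in place of 3-bromophenyl on the nitrogen gives a 1.0-fold lower number from compound 2 to compound 3 (0.01 log units; within the scatter), the first reading of a change in just one place. At this position, therefore, the two groups cannot be told apart, even though they differ in the substituent they carry and in where it is named on the phenyl ring. No measurement available here bears on this result.

Still open, as far as these compounds go, is whether a different kind of group on this nitrogen, such as a pyridyl ring or a phenyl carrying an amine or a carboxylic acid, would move the number beyond the scatter. Also open, from the compounds shown here alone, is whether changing the rest of the molecule, for example replacing the thiourea with a urea, would shift the number.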